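Chloro substitution on the fused-ring member of the series

A few compounds are considered here, and "the series" means these few. Any claim that something is new, unique, unknown or untested is made for them only; others in the source may bear on it.

Measured so far in an assay on a cell-free system (plasma) for inhibition of Dipeptidyl peptidase 4 (Rattus norvegicus), read by fluorescence; on this read-out lower numbers stand for stronger inhibition and higher numbers for weaker inhibition:
compound 1 `CCOC(=O)CN(Cc1ccc(C#N)cc1)[C@@H]1CN[C@H](C(=O)N2CCSC2)C1`: 15.3 nM
compound 2 `N#Cc1ccc(CN(CC(=O)O)[C@@H]2CN[C@H](C(=O)N3CCSC3)C2)cc1`: 16.3 nM
compound 3 `O=C([C@@H]1C[C@H](N2CCc3ccccc32)CN1)N1CCSC1`: 19.5 nM

Compound 3 stands at the highest of the three numbers in this assay, but its gap to compound 2, the nearest, and to compound 1, the furthest, both lie within the scatter, so the three compounds cannot be ordered. Among the measured compounds shown here, the only step between two measured compounds, a 1.1-fold higher number from compound 1 to compound 2 (0.03 log units; within the scatter), concerns the group on the oxygen of the carbonyl side chain and lies within the scatter as well.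

Compound 4 `O=C([C@@H]1C[C@H](N2CCc3cc(Cl)ccc32)CN1)N1CCSC1` differs from compound 3 in one place: chloro in place of hydrogen on an aromatic carbon. For the measured compounds named here, no measured step touches the aromatic ring of the fused system of compound 3, so nothing bears directly on this change. With no guidance beyond the narrow spread of the three numbers, the step of a 1.1-fold lower number from compound 3 to compound 4 (0.03 log units; within the scatter) is expected to stay within the scatter. For compound 4 a value of about 18 nM is estimated, most plausibly between 7 nM and 50 nM.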

Compound 4, half-maximal inhibitory concentration: 13.4 nM
Compound 4: middle estimate off by 1.3-fold (0.13 log units), on the high side, within the range that was stated.
By their numbers in this assay, from the lowest: compounds 4, 1, 2 and 3 (each within the scatter of the next).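

In this assay, among the compounds shown here, a 1.5-fold lower number from compound 3 to compound 4 (0.16 log units; within the scatter) is the first reading on the aromatic ring of the fused system, and it shows that chloro can sit on this carbon, meta to a fused ring and para to a fused ring, without a shift that can be told from the scatter. Compound 4 thus keeps its value in the same narrow band as compounds 1, 2 and 3, so this position accepts one chlorine atom in place of hydrogen with no readable gain or loss. Nothing on hand explains the step or assigns any effect to the chloro group.

Open, going by these compounds, is whether a larger or different group here, such as methoxy, an amine or a carboxylic acid, would also stay within the scatter. Also open, on these data alone, is how chloro behaves on the other aromatic carbons of the fused system.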